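This account rests on a few compounds, and the source may have more. Where it says the series, first, only, none or still open, it means among the compounds named here.

The measured compounds and their values in this assay:

compound 1 `O=c1[nH]cnc2c1c(-c1cccs1)cn2[C@@H]1O[C@H](CO)[C@@H](O)[C@H]1O` — > 20000 nM
compound 2 `O=c1[nH]cnc2c1c(-c1ccco1)cn2[C@@H]1O[C@H](CO)[C@@H](O)[C@H]1O` — > 20000 nM
compound 3 `O=c1[nH]cnc2c1c(-c1ccccc1)cn2[C@@H]1O[C@H](CO)[C@@H](O)[C@H]1O` — not yet measured

Compound 1 `O=c1[nH]cnc2c1c(-c1cccs1)cn2[C@@H]1O[C@H](CO)[C@@H](O)[C@H]1O` carries thiophen-2-yl on the shared core. In a functional assay on HCT-116 cells (Homo sapiens), read by MTT assay, with a stated time of 72 h (on this read-out lower numbers stand for stronger inhibition and higher numbers for weaker inhibition), compound 1 gives > 20000 nM, which is a limit of the assay and not a number. Compound 2 `O=c1[nH]cnc2c1c(-c1ccco1)cn2[C@@H]1O[C@H](CO)[C@@H](O)[C@H]1O` carries furan-2-yl in its place. In this assay compound 2 gives > 20000 nM, again a limit rather than a number. The step that the two limits leave unreadable from compound 1 to compound 2 is therefore not readable in either direction. Within the data shown here, compound 2 thus stands at the limit of the assay, and the only other value shown is the same limit, as the limit of > 20000 nM in this assay, at which 2 of the 2 values shown sit, records.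

Compound 3 `O=c1[nH]cnc2c1c(-c1ccccc1)cn2[C@@H]1O[C@H](CO)[C@@H](O)[C@H]1O` is the next member of the series. Its change from compound 2 is phenyl in place of furan-2-yl on an aromatic carbon. Among the measured compounds shown here, the one measured step, from compound 1 to compound 2, bears on it only as an exchange of one aryl group for another at the same carbon, and its size cannot be read. For the measured compounds named here, no measured step therefore gives a size to expect in this assay. On that basis compound 3 is expected to remain at the limit as well, with an estimate of 25000 nM between 8000 nM and 80000 nM. The step that the limit leaves unreadable from compound 2 to compound 3 is accordingly expected to be none beyond the scatter, a phenyl in place of furan-2-yl.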

Compound 3, half-maximal inhibitory concentration: > 20000 nM
Compound 3 was reported as a limit (the forecaster's own chance of this, stated with the estimate: 85%); the middle value lies beyond the limit too.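

In this assay compound 3 gives > 20000 nM, a limit of the assay and not a number, so the steps among compound 1, compound 2 and compound 3 cannot be read. The compounds shown leave open how thiophen-2-yl, furan-2-yl and phenyl rank against one another, since all three compounds share one value: the limit of > 20000 nM in this assay, at which 3 of the 3 values shown sit.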